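Swapping the Hydroxy for a Methyl on the Core

A few compounds are considered here, and "the series" means these few. Any claim that something is new, unique, unknown or untested is made for them only; others in the source may bear on it.

Compound 1 `COc1cc(C2CCN(CC(N)=O)CC2)ccc1Nc1ncc2ccc(-c3ccccc3N(C)S(C)(=O)=O)n2n1` is the reference point here. In an in vitro ADME assay on microsomes from liver (Mus musculus, strain CD1) for metabolic stability, using NADPH, with a stated time of 10 min, tested at 0.5 uM (on this read-out higher numbers stand for a longer-lived compound and lower numbers for a shorter-lived compound), compound 1 gives 0.483 h. Compound 2 `COc1cc(C2CCN(CC(N)=O)CC2)ccc1Nc1ncc2c(O)cc(-c3ccccc3N(C)S(C)(=O)=O)n2n1` differs from it in one place, and in this assay compound 2 reaches only a limit of the measurement, < 0.0834 h. That single change, an at least 5.7-fold lower number from compound 1 to compound 2 (0.76 log units; beyond the scatter), therefore rests on the limit of < 0.0834 h in this assay, at which 1 of the 2 values shown sits, rather than on a measured number, so compound 2 is known only to lie at or beyond that edge. Compound 3 `COc1cc(C2CCN(CC(N)=O)CC2)ccc1Nc1ncc2c(C)cc(-c3ccccc3N(C)S(C)(=O)=O)n2n1` takes the next step from compound 2: methyl in place of hydroxy on an aromatic carbon. Among the measured compounds shown here, the one measured step that bears on this change is the step that introduced the hydroxy, an at least 5.7-fold lower number from compound 1 to compound 2 (0.76 log units; beyond the scatter); nothing measured shows what a methyl does at this position. Taking the hydroxy out again is expected to pull the reading back toward compound 1, though how far a methyl allows is uncertain, so for compound 3 the expected step from compound 2 is an at least 3.5-fold higher number from compound 2 to compound 3 (0.55 log units; beyond the scatter). The estimate for compound 3 in this assay is 0.3 h, with a range from 0.08 h to 0.8 h.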

Compound 3, half-life: > 0.666 h
Compound 3: a limit, no number; the forecaster's own chance of this, stated with the estimate: 25%; at least 2.2-fold (0.34 log units) between middle value and limit.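

In this assay, compound 3 gives a limit of the measurement and not a number, > 0.666 h. The earlier compounds shown here showed only that adding hydroxy on this aromatic carbon lowers the half-life, and putting methyl there instead gives an at least 7.9-fold higher number from compound 2 to compound 3 (0.90 log units; beyond the scatter), so the loss at compound 2 goes with hydroxy and not with just any group at this position. Set against plain hydrogen, methyl gives an at least 1.3-fold higher number from compound 1 to compound 3 (0.13 log units; that floor lies within the scatter); that floor lies within the usual scatter, so methyl is shown to cost nothing here, but it is not shown to be a gain, and the reading for compound 3 is held at an edge of the assay: the limit of > 0.666 h in this assay, at which 1 of the 3 values shown sits.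

What remains open is how long compound 3 actually lasts in this assay, and so how large either step truly is, and the compounds shown do not tell why hydroxy and methyl part so widely. On these data alone, it is also open whether other groups on this carbon, such as an amine, a carboxylic acid or a longer chain like ethyl, would behave like the hydroxy or like the methyl.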